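Chloro in place of methoxy: expected effect on kinase inhibition

The compounds below may be only part of what the source reports. "The series", "measured", "known", "first", "only" and "open" are said of these compounds alone.

Compound 2 `COC(=O)Nc1cc(-c2cnc(OC[C@@](C)(N)CC(C)C)c(OC)c2)ccn1` stands at the highest number of the three values recorded so far: in an assay on isolated protein for inhibition of AP2-associated protein kinase 1 (Homo sapiens), with a stated time of 3 h, in the presence of a further agent that is not named here (on this read-out higher numbers stand for weaker inhibition and lower numbers for stronger inhibition), compound 2 gives 3.8 nM. Compound 1 `COC(=O)Nc1cc(-c2cc(Cl)c(OC[C@@](C)(N)CC(C)C)cn2)ccn1` gives 1.1 nM in this assay, and compound 3 `CC(=O)Nc1cc(-c2cc(F)c(OC[C@@H](N)CC(C)C)cc2F)ccn1` gives 1.3 nM; both lie beyond the scatter from compound 2, so compound 2 is the weakest inhibitor of the three measured. Compound 4 `COC(=O)Nc1cc(-c2cnc(OC[C@@](C)(N)CC(C)C)c(Cl)c2)ccn1` has not been measured. It differs from compound 2 by chloro in place of methoxy on an aromatic carbon. For the measured compounds named here, no pair of measured compounds isolates this change. Compound 1 carries a chloro group and returns the lowest number, but its ring arrangement is not that of compound 2, so it is only a loose pointer. The change is expected to lower the number somewhat, a 1.9-fold lower number from compound 2 to compound 4 (0.28 log units; within the scatter). Compound 4 is estimated at 2 nM, with a range of 0.8 nM to 5 nM.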

Compound 4, half-maximal inhibitory concentration: 0.4 nM
Compound 4: the middle estimate sits 5.0-fold (0.70 log units) above what was measured; measured number outside the range, below it.
By their numbers in this assay, from the lowest: compound 4; then compounds 1 and 3 (each within the scatter of the next); then compound 2.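

For the compounds shown here, at the aromatic carbon ortho to the (2-amino-2,4-dimethylpentyl)oxy group, chloro in place of methoxy gives a 9.5-fold lower number from compound 2 to compound 4 (0.98 log units; beyond the scatter) in the only single-place comparison so far. Methoxy is therefore not required at this position for a low number, and compound 4 reaches 0.4 nM as the lowest value in the series. No measured evidence accounts for the size of this step.

On these data alone, whether fluoro, methyl or nitrile at this position would match chloro remains open. So does whether the same exchange would give a similar step on the core of compound 1.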